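Isoxazole-fused acid series: step from compound 3 to compound 4

This account rests on a few compounds, and the source may have more. Where it says the series, first, only, none or still open, it means among the compounds named here.

Measured compounds:
- Compound 1 `CN(C)C(=O)/C=C/c1ccc2noc(-c3ccccc3)c2c1`: in an assay for inhibition of inositol hexakisphosphate kinase 3 (Homo sapiens), read by colorimetric assay, coupled enzyme assay and malachite green, with a stated time of 120 min, in the presence of a further agent that is not named here (a lower number here means a stronger inhibitor, a higher number a weaker inhibitor), compound 1 gives > 100000 nM.
- Compound 2 `O=C(O)c1ccc2noc(-c3ccc(Cc4ccccc4)cc3)c2c1`: in this assay compound 2 gives 1290 nM.
- Compound 3 `O=C(O)c1ccc2noc(-c3cccc(C(F)(F)F)c3)c2c1`: in this assay compound 3 gives 4620 nM.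

The value for compound 1 is a limit of this assay, not a number, as recorded in the limit of > 100000 nM in this assay, at which 1 of the 3 values shown sits. Of the two numbers available, compound 3 gives the higher one; compound 2 gives the lower, and the gap between them lies beyond the scatter. Both carry the acid on the shared core, whereas compound 1 does not and sits at the limit.

Compound 4 `O=C(O)c1ccc2noc(-c3cccc(Oc4ccccn4)c3)c2c1` is not yet measured in this assay. It differs from compound 3 as follows: (pyridin-2-yl)oxy in place of trifluoromethyl on an aromatic carbon. Within the data shown here, no pair of measured compounds differs in one place, so no measured step guides this change directly; the only pointer is that compound 2, carrying a larger aromatic extension on the phenyl than compound 3, gives the lower of the two numbers.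

On that basis compound 4 is expected to give a somewhat lower number than compound 3 in this assay, an estimated step of a 2.1-fold lower number from compound 3 to compound 4 (0.32 log units; beyond the scatter). The estimate for compound 4 is 2200 nM, with a range from 600 nM to 8000 nM.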

Compound 4, half-maximal inhibitory concentration: 10900 nM
Beside the measured number, compound 4's estimate is 5.0-fold (0.70 log units) below it, outside the stated range (above it).
By their numbers in this assay, from the lowest: compound 2; then compound 3; then compound 4. At a limit, above all of these: compound 1.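

In this assay, the one-place change from trifluoromethyl to (pyridin-2-yl)oxy gives the series its first direct reading of this position, an aromatic carbon meta to a large group: a 2.4-fold higher number from compound 3 to compound 4 (0.37 log units; beyond the scatter), a modest step that lies beyond the scatter. Putting an aromatic ring at this position thus does not by itself lower the number, although the larger group still leaves compound 4 with a measured value rather than a limit of the assay. Nothing measured in the compounds shown accounts for the direction or size of this step.

A phenoxy group and a 3-pyridyloxy group at the same position would help separate the contributions of the ring nitrogen and its placement, while a benzyl group would test the oxygen link. Going by these compounds, compound 1 differs from the other compounds in more than one place, so the part played by the carboxylic acid stays open, and a primary amide or a tetrazole on the otherwise unchanged structure of compound 3 would address it.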